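This account rests on a few compounds, and the source may have more. Where it says the series, first, only, none or still open, it means among the compounds named here.

Measured in a functional assay on HCT-116 cells (Homo sapiens) for inhibition, read by sulforhodamine B assay, with a stated time of 48 h; a higher number here means a weaker inhibitor of growth, a lower number a stronger inhibitor of growth:
- compound 1 `COc1cc(-c2nn(-c3cccc(NC(=O)Nc4cc(C(F)(F)F)cc(C(F)(F)F)c4)c3)cc2-c2ccncc2)ccc1Cl`: 643 nM
- compound 2 `COc1cc(-c2nn(-c3cccc(NC(=O)c4cccc(C(F)(F)F)c4)c3)cc2-c2ccncc2)ccc1Cl`: 1670 nM
- compound 3 `COc1cc(-c2nn(-c3cccc(NC(=O)c4ccc(Cl)c(C(F)(F)F)c4)c3)cc2-c2ccncc2)ccc1Cl`: 2490 nM

Compound 2 sits within the scatter of compound 3, while compound 1 shows a lower number, beyond the scatter. The next compound is compound 4 `COc1cc(-c2nn(-c3cccc(NC(=O)c4ccccc4)c3)cc2-c2ccncc2)ccc1Cl`, with hydrogen in place of trifluoromethyl on an aromatic carbon. Among the measured compounds shown here, the only measured single-place step is a 1.5-fold higher number from compound 2 to compound 3 (0.17 log units; within the scatter), which swaps hydrogen for chloro and does not measure the loss of trifluoromethyl. It offers only weak guidance, so no step beyond the scatter is expected in this assay. The expected change is a 1.4-fold higher number from compound 2 to compound 4 (0.14 log units; within the scatter). Compound 4 is estimated at 2300 nM, with an expected range of 900 nM to 6500 nM.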

Compound 4, concentration for 50% growth inhibition: 500 nM
For compound 4 the middle estimate is 4.6-fold (0.66 log units) above the measured one, outside the stated range (below it).
By their numbers in this assay, from the lowest: compounds 4 and 1 (each within the scatter of the next); then compounds 2 and 3 (each within the scatter of the next).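

In this assay, among the compounds shown here, hydrogen in place of trifluoromethyl on the aromatic carbon gives a 3.3-fold lower number from compound 2 to compound 4 (0.52 log units; beyond the scatter), the first single-place step beyond the scatter. Phenyl in place of 4-chloro-3-(trifluoromethyl)phenyl on the carbonyl carbon gives a 5.0-fold lower number from compound 3 to compound 4 (0.70 log units; beyond the scatter), so both substituted benzamides here carry higher numbers than the plain benzoyl compound. No measurement available here accounts for these steps.

Going by these compounds, whether a methyl, an amine or a carboxylic acid at this aromatic carbon would stay near compound 4 remains open. Also open, on these data alone, is whether the same change would hold on the urea of compound 1.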